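This account rests on a few compounds, and the source may have more. Where it says the series, first, only, none or still open, it means among the compounds named here.

In a functional assay on HepG2 cells (Homo sapiens) for cytotoxicity, read by MTT assay, with a stated time of 48 h (on this read-out higher numbers stand for weaker inhibition and lower numbers for stronger inhibition), two compounds that share one core have been measured so far. Compound 1 `O=C1/C(=C\c2ccc([N+](=O)[O-])cc2)S/C(=N/c2ccccc2)N1Cc1ccncc1` gives 18900 nM, and compound 2 `CC(C)c1ccc(/C=C2/S/C(=N/c3ccccc3)N(Cc3ccncc3)C2=O)cc1` gives 32300 nM. These two numbers lie within the scatter of each other, so compound 2 cannot be told apart from compound 1 on this read-out.

Compound 3 `O=C1/C(=C\c2ccc(O)c(O)c2)S/C(=N/c2ccccc2)N1Cc1ccncc1` keeps the shared core but carries 3,4-dihydroxyphenyl in place of 4-isopropylphenyl on a double-bonded chain carbon bound to a double-bonded ring carbon.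

Within the data shown here, only one measured step bears on this change. Replacing nitro with isopropyl on an aromatic carbon gave a 1.7-fold higher number from compound 1 to compound 2 (0.23 log units; within the scatter). Neither measured compound carries a hydroxyl group, so this single step is only a rough guide, and a larger move cannot be ruled out. Even so, no shift beyond the scatter is expected in this assay. The estimated change is a 1.5-fold lower number from compound 2 to compound 3 (0.17 log units; within the scatter). For compound 3 the estimated value is 22000 nM, with an expected range from 7000 nM to 60000 nM.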

Compound 3, half-maximal inhibitory concentration: 16200 nM
Estimate against measurement, compound 3: 1.4-fold (0.13 log units) above; measured number inside the range.
By their numbers in this assay, from the lowest: compounds 3, 1 and 2 (each within the scatter of the next).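

In this assay, among these compounds, compound 3 is the only one of the three compounds to carry hydrogen-bond donors on a double-bonded chain carbon bound to a double-bonded ring carbon, yet placing 3,4-dihydroxyphenyl there instead of 4-isopropylphenyl gives a step no larger than the usual spread of repeat measurements (a 2.0-fold lower number from compound 2 to compound 3 (0.30 log units; within the scatter)). Set against the 4-nitrophenyl group, the 3,4-dihydroxyphenyl group also gives a step that stays inside that spread (a 1.2-fold lower number from compound 1 to compound 3 (0.07 log units; within the scatter)), so three differently substituted phenyl groups at this place cannot be told apart on this read-out, and none of them stands out as better or worse. Nothing available here explains why these groups read alike.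

Going by these compounds, all three compounds keep an aromatic ring at this place, so it remains open whether an amine or a carboxylic acid on that ring, or a longer chain in its stead, would give a step beyond the scatter. The rest of the shared core is the same in all three, so they say nothing about how a change at any other place would read.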